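Swapping bromo for methoxy in compound 1

A few compounds are considered here, and "the series" means these few. Any claim that something is new, unique, unknown or untested is made for them only; others in the source may bear on it.

Values from a functional assay on KG-1 cells (Homo sapiens) for cytotoxicity, read by luminescence and CellTiter-Glo, with a stated time of 3 days (a higher number here means a weaker inhibitor, a lower number a stronger inhibitor), for the compounds measured so far
Compound 1 `N#Cc1ccc(NC(=O)c2cccc(Br)c2O)cc1` gives 3260 nM
Compound 2 `O=C(Nc1cc(Cl)cc(Cl)c1)c1cc(F)ccc1O` gives 780 nM

Compound 1 holds the higher number of the two, and its gap to compound 2 lies beyond the scatter. Compound 3 `COc1cccc(C(=O)Nc2ccc(C#N)cc2)c1O` carries methoxy in place of bromo on an aromatic carbon, ortho to a hydroxy group (methoxy in place of bromo on an aromatic carbon). Among the measured compounds shown here, no measured pair shows this change, so only a modest rise in the number is expected in this assay and it may stay within the scatter. The expected move is a 1.5-fold higher number from compound 1 to compound 3 (0.19 log units; within the scatter) on this estimate. Compound 3 is estimated at 5000 nM within an expected range from 1800 nM to 14000 nM when measured.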

Compound 3, half-maximal inhibitory concentration: > 10000 nM
Compound 3 ended at the assay's limit; the forecaster's own chance of this, stated with the estimate: 15%; middle value at least 2.0-fold (0.30 log units) away from the limit.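

In this assay, compound 3 gives > 10000 nM, which is a limit of the assay and not a number. Methoxy in place of bromo on this aromatic carbon, ortho to a hydroxy group, gives an at least 3.0-fold higher number from compound 1 to compound 3 (0.48 log units; beyond the scatter), so this position on the core of compound 1 is sensitive to the change. The full size of the step stays unknown, as it rests on a limit: the limit of > 10000 nM in this assay, at which 1 of the 3 values shown sits.

As far as these compounds go, what an amine or a methyl group on this carbon would give stays open. So does whether the bromo leaving or the methoxy entering accounts for the rise.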